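Swapping the aryl substituent for an oxazolylmethoxy ether

This account rests on a few compounds, and the source may have more. Where it says the series, first, only, none or still open, it means among the compounds named here.

Compound 3 `Cc1nn(-c2ncnc3nc[nH]c23)c2c1C(c1ccc(OC(C)C)cc1)CC(=O)N2` gives 18 nM in a functional assay on HEK293 cells for agonist activity at G-protein coupled receptor 39 (Homo sapiens), read by scintillation proximity assay and inositol phosphate accumulation, with a stated time of 75 min, in the presence of a further agent that is not named here (on this read-out lower numbers stand for an effect already at smaller amounts and higher numbers for an effect only at larger amounts of compound), the highest of the three numbers shown: compound 1 `Cc1nn(-c2ncnc3nc[nH]c23)c2c1C(OCc1ccccc1C#N)CC(=O)N2` gives 8 nM and compound 2 `Cc1nn(-c2ncnc3nc[nH]c23)c2c1C(OCc1ccc(C(C)C)cc1)CC(=O)N2` gives 5 nM. Compound 4 `Cc1noc(C)c1COC1CC(=O)Nc2c1c(C)nn2-c1ncnc2nc[nH]c12` carries (3,5-dimethyl-1,2-oxazol-4-yl)methoxy in place of 4-isopropoxyphenyl on a saturated ring carbon. Going by the values given here, two measured steps bear on this change. The step of a 2.3-fold higher number from compound 1 to compound 3 (0.35 log units; beyond the scatter) shows that trading an oxygen-linked benzyl group for a directly bound aryl ring raised the number modestly, while a 1.6-fold lower number from compound 1 to compound 2 (0.20 log units; within the scatter) shows that the aryl part of such an ether can be varied without effect beyond the scatter. Returning to an oxygen-linked ring is therefore expected to lower the number, and for compound 4 the expected step is a 2.0-fold lower number from compound 3 to compound 4 (0.30 log units; within the scatter), giving an estimate of 9 nM with a range from 3 nM to 30 nM.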

Compound 4, half-maximal effective concentration: 5 nM
Compound 4: the middle estimate sits 1.8-fold (0.26 log units) above what was measured; measured number inside the range.
By their numbers in this assay, from the lowest: compounds 2, 4 and 1 (each within the scatter of the next); then compound 3.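

At the saturated ring carbon, the (3,5-dimethyl-1,2-oxazol-4-yl)methoxy group gives a 3.6-fold lower number from compound 3 to compound 4 (0.56 log units; beyond the scatter), so the ether at this position need not carry a six-membered aromatic ring of carbon only. Among the ethers, a five-membered aromatic ring with 2 hetero atoms stays within the scatter of the earlier aryl groups, with no change at the digits printed from compound 2 to compound 4 (within the scatter) and a 1.6-fold lower number from compound 1 to compound 4 (0.20 log units; within the scatter). No measurement shown accounts for these results. As far as these compounds go, whether this ether also accepts an amine or a carboxylic acid on its ring, or a longer chain in place of the methoxy link, remains open.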